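Thiophen-2-yl for furan-2-yl: working notes on compound 4

The source may hold more compounds than are shown below. What is called first, only, known or untested is meant among the compounds shown, and "the series" means these compounds.

Of the compounds shown here, three have been measured so far. In a functional assay on COLO 205 cells (Homo sapiens) for inhibition, read by sulforhodamine B assay, with a stated time of 48 h, tested at 50 uM (on this read-out lower numbers stand for less inhibition of growth and higher numbers for more inhibition of growth at the one concentration tested), compound 1 `COc1cc(/C=C/C(=O)/C=C/c2ccco2)ccc1OCc1cn(CCCOc2cc(=O)oc3ccccc23)nn1` gives 59%. Compound 2 `COc1cc(/C=C/C(=O)/C=C/c2cccc3ccccc23)ccc1OCc1cn(CCCCOc2cc(=O)oc3ccccc23)nn1` gives 50%, within the scatter of compound 1. Compound 3 `COc1cc(/C=C/C(=O)/C=C/c2cc(OC)c(OC)c(OC)c2)ccc1OCc1cn(CCOc2cc(=O)oc3ccccc23)nn1` gives 86%, beyond the scatter of compound 1.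

Compound 4 `COc1cc(/C=C/C(=O)/C=C/c2cccs2)ccc1OCc1cn(CCCOc2cc(=O)oc3ccccc23)nn1` carries thiophen-2-yl in place of furan-2-yl on a double-bonded chain carbon bound to a double-bonded chain carbon. Within the data shown here, no measured pair isolates this change, so the data give no direct guide. No step beyond the scatter is expected in this assay, in either direction.

The estimated step of a number 3 percentage points higher from compound 1 to compound 4 (within the scatter) is small. For compound 4 the expected value is 62%, with an estimated range of 45% to 78%.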

Compound 4, percent growth inhibition at one concentration: 55%
Beside the measured number, compound 4's estimate is 7 percentage points above it; low and high end bracket the measured number.
By their numbers in this assay, from the lowest: compounds 2, 4 and 1 (each within the scatter of the next); then compound 3.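

Among these compounds, this is the first pair to isolate thiophen-2-yl in place of furan-2-yl on a double-bonded chain carbon bound to a double-bonded chain carbon, and in this assay it gives a number 4 percentage points lower from compound 1 to compound 4 (within the scatter) with the rest of the structure unchanged. At this position, exchanging one five-membered aromatic ring for the other therefore does not move growth inhibition beyond the scatter. No measured data are available to account for this result.

As far as these compounds go, whether a pyridin-2-yl group at this place would behave the same remains open. Compound 3 differs from compound 1 in more than one place, so its higher value cannot yet be assigned to a single change.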